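This account rests on a few compounds, and the source may have more. Where it says the series, first, only, none or still open, it means among the compounds named here.

Measured in a functional assay on ECa-109 cells for antiproliferative activity against ECa-109 cell line (Homo sapiens), read by MTT assay, with a stated time of 48 h; a lower number here means a stronger inhibitor, a higher number a weaker inhibitor:
- compound 1 `COc1ccc(CN(C(=O)CSc2ccccn2)c2cc(OC)c(OC)c(OC)c2)cc1`: 16000 nM
- compound 2 `COc1ccc(CN(C(=O)CSC2=CN=NC2C)c2cc(OC)c(OC)c(OC)c2)cc1`: > 80000 nM (a limit, not a number)

For compound 2 there is only the limit of > 80000 nM in this assay, at which 1 of the 2 values shown sits, and no number. The change to compound 3 `COc1ccc(CN(C(=O)CSc2nc3ccc(OC)cc3s2)c2cc(OC)c(OC)c(OC)c2)cc1` is a group of 11 heavy atoms (8 carbon, 1 nitrogen, 1 oxygen, 1 sulfur; one five-membered aromatic ring with 2 hetero atoms, one six-membered aromatic ring of carbon only) in place of a group of 6 heavy atoms (4 carbon, 2 nitrogen; one five-membered non-aromatic ring with 2 hetero atoms), on a sulfur and the rest of the structure stays the same. For the measured compounds named here, one measured step bears on it, at the same sulfur: an at least 5.0-fold higher number from compound 1 to compound 2 (0.69 log units; beyond the scatter) as the aromatic ring of compound 1 gives way to the non-aromatic ring of compound 2. Compound 3 again carries aromatic rings on that sulfur, as does compound 1 at 16000 nM so a step of similar size toward a lower number in this assay is expected, though a single step is thin support. The expected change is an at least 4.0-fold lower number from compound 2 to compound 3 (0.60 log units; beyond the scatter) in this estimate. For compound 3 the estimated value is 20000 nM with an expected range from 5000 nM to 70000 nM in this reading.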

Compound 3, half-maximal inhibitory concentration: > 80000 nM
Compound 3 was reported as a limit (the forecaster's own chance of this, stated with the estimate: 20%); middle value at least 4.0-fold (0.60 log units) away from the limit.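

In this assay compound 3 gives > 80000 nM, which is a limit and not a number. Aromatic rings on this sulfur are thus not enough on their own: 6-methoxy-1,3-benzothiazol-2-yl in place of pyridin-2-yl brings an at least 5.0-fold higher number from compound 1 to compound 3 (0.69 log units; beyond the scatter), while the step between the two limits cannot be read. Among the compounds shown, only the one carrying pyridin-2-yl gives a number, and the others offer no measured size of change at this position: the limit of > 80000 nM in this assay, at which 2 of the 3 values shown sit.

From the compounds shown here alone, it remains open whether the fused ring or its methoxy group accounts for the step from pyridin-2-yl. Also open, going by these compounds, is how a plain phenyl, or a 1,3-benzothiazol-2-yl without the methoxy, would read on the same sulfur in this assay.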